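This account rests on a few compounds, and the source may have more. Where it says the series, first, only, none or still open, it means among the compounds named here.

In a functional assay on PC-3 cells (Homo sapiens) for antiproliferative activity, read by CCK-8 assay, with a stated time of 6 days (a higher number here means a weaker inhibitor, a lower number a stronger inhibitor), compound 2 `CCN(c1cccc(-n2ccnc2)c1)c1ccc(C#N)c(Cl)c1` gives > 30000 nM, which is a limit of the assay and not a number. Compound 1 `CCN(c1ccc(C#N)c(Cl)c1)c1cc(-c2cncnc2)ccc1C` gives > 30000 nM, also a limit. Together they make up (the limit of > 30000 nM in this assay, at which 2 of the 2 values shown sit), so neither compound supplies an exact starting value. Compound 3 `CCN(c1cccc(-c2cncnc2)c1)c1ccc(C#N)c(Cl)c1` changes one group of compound 2, with pyrimidin-5-yl in place of 1H-imidazol-1-yl on an aromatic carbon, meta to a large group: pyrimidin-5-yl in place of 1H-imidazol-1-yl on an aromatic carbon. Within the data shown here, no measured pair shows what a change of this kind does. Among the measured compounds shown here, with the limit of > 30000 nM in this assay, at which 2 of the 2 values shown sit, as the only guide, no step beyond the usual scatter is expected in this assay, and another limit is the likeliest report. The expected change is a number no higher from compound 2 to compound 3 (the limit leaves the size open), a rough estimate set against a limit. For compound 3 the estimated value is 30000 nM, with an expected range from 10000 nM to 60000 nM.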

Compound 3, half-maximal inhibitory concentration: > 30000 nM
Compound 3 gave a limit, no number; the forecaster's own chance of this, stated with the estimate: 75%; the middle value lies on the limit itself.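

Compound 3, like compound 1 and compound 2, gives only a limit and not a number in this assay, so the steps from compound 1 and from compound 2 to compound 3 cannot be read. How strongly any of the three inhibits stays open, and so does whether either change matters: the limit of > 30000 nM in this assay, at which 3 of the 3 values shown sit.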